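The source may report more compounds than this note shows. Statements on the series, on what has been measured and on what is new or still open speak of the compounds shown alone.

Of the compounds shown here, two have been measured in an assay on CHO cells for displacement of a labelled ligand from Substance-P receptor (Homo sapiens); a higher number here means a weaker inhibitor, a lower number a stronger inhibitor. Compound 1, with structure `CC(=O)N1CCC(C(=O)N2C[C@H](C(=O)N(C)C(C)(C)c3cc(C(F)(F)F)cc(C(F)(F)F)c3)[C@@H](c3ccc(F)cc3C)C2)CC1`, gives 0.05 nM in this assay. Compound 2, with structure `CN(Cc1cc(C(F)(F)F)cc(C(F)(F)F)c1)C(=O)[C@H]1CN(C(=O)C2CCNCC2)C[C@@H]1c1ccccc1`, gives 4.1 nM in this assay, the higher of the two numbers, and the two structures differ in several places, so the gap between them cannot be tied to a single change. Compound 3, with structure `CN(Cc1cc(C(F)(F)F)cc(C(F)(F)F)c1)C(=O)[C@H]1CN(C(=O)NC2CCCCC2)C[C@@H]1c1ccccc1`, has not yet been measured. It differs from compound 2 in one place: cyclohexylamino in place of piperidin-4-yl on a carbonyl carbon, that is, a (piperidin-4-yl)carbonyl group becomes a cyclohexylcarbamoyl group. Among the compounds with values here, no measured pair shows what such a change does here, so the expected step from compound 2 to compound 3 is estimated as small, a 1.2-fold higher number from compound 2 to compound 3 (0.09 log units; within the scatter), not clearly beyond the scatter in either direction. Compound 3 is therefore expected to give about 5 nM in this assay, within a range of 1 nM to 25 nM.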

Compound 3, half-maximal inhibitory concentration: 0.79 nM
The estimate for compound 3 lay 6.3-fold (0.80 log units) above the measured number; measured number below the stated range.
By their numbers in this assay, from the lowest: compound 1; then compound 3; then compound 2.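

Putting cyclohexylamino in place of piperidin-4-yl on the carbonyl carbon produces a 5.2-fold lower number from compound 2 to compound 3 (0.72 log units; beyond the scatter) in this assay, so the group held on this carbonyl carbon does affect the number, which the earlier pair, differing in several places, could not show. The entering group has a ring of carbon only and no hydrogen-bond acceptor, yet it keeps a hydrogen-bond donor, so a ring nitrogen is not needed for a number this low in this series. No measurement here explains the step.

The change alters two things at once, the ring itself and the amino nitrogen now attached to the carbonyl carbon, and these compounds cannot separate them. A piperidin-4-ylamino group or a cyclohexyl group on the same carbonyl carbon would pull those two parts apart.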